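The compounds below may be only part of what the source reports. "The series", "measured", "known", "first", "only" and "open" are said of these compounds alone.

Compound 1 `CC(=O)Nc1cccc(-c2ccc(CO)cc2)c1` in an assay for binding affinity to 17-beta-hydroxysteroid dehydrogenase type 1 (Homo sapiens), with a stated time of 20 min, tested at 1 uM (a lower number here means less inhibition, a higher number more inhibition at the concentration tested (going by the name of the read-out)), gives < 10%, which is a limit of the assay and not a number.
Compound 2 `CS(=O)(=O)Nc1ccc(-c2ccc(CO)cc2)cc1` in this assay gives < 10%, again a limit of the assay.
Compound 3 `CC(=O)Nc1cccc(-c2ccc(O)cc2)c1` in this assay gives < 10%, also a limit of the assay.

Compound 1 and compound 3 share a core and differ in one place only: hydroxy in place of hydroxymethyl on an aromatic carbon. The step that the two limits leave unreadable from compound 1 to compound 3 cannot be read as a size, because every value shown sits at the limit (the limit of < 10% in this assay, at which 3 of the 3 values shown sit). All that can be said is that the change left compound 3, like compound 1, at the limit.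

The same change, (hydroxy in place of hydroxymethyl on an aromatic carbon), leads from compound 2 to the unmeasured compound 4 `CS(=O)(=O)Nc1ccc(-c2ccc(O)cc2)cc1`. The place around the change is described in the same words for both pairs. The difference between the core of compound 1 and the core of compound 2 is not broken down here, so the two pairs are linked only by the change they have in common.

For compound 4 the step that the limit leaves unreadable from compound 2 to compound 4 is expected to be small, because the same change from compound 1 to compound 3 gave a step that the two limits leave unreadable from compound 1 to compound 3 with both partners at the limit (the limit of < 10% in this assay, at which 3 of the 3 values shown sit). Compound 4 is therefore estimated at 5%, expected to fall between 0% and 15%, most probably reported as a limit once more.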

Compound 4, a percentage reported as inhibition, at one concentration (the size of the read-out at that concentration, not a potency): < 10%
Compound 4: no number, only a limit; the forecaster's own chance of this, stated with the estimate: 80%; the middle value is on the limit's open side.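

In this assay compound 4 gives < 10%, a limit of the assay and not a number. No size can be read for the step from compound 2 to compound 4, because both compounds stand at the limit: the limit of < 10% in this assay, at which 4 of the 4 values shown sit.

The compounds shown leave open whether hydroxy in place of hydroxymethyl changes inhibition at all, and which change to them would give a readable value in this assay.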